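Fluoro to Methanesulfonamido on a Shared Biaryl Core

The source may report more compounds than this note shows. Statements on the series, on what has been measured and on what is new or still open speak of the compounds shown alone.

Compound 1 `Oc1cccc2cc(-c3ccc(F)cc3)ccc12` gives < 10% in an assay for binding affinity to 17-beta-hydroxysteroid dehydrogenase type 2 (Homo sapiens), with a stated time of 20 min, tested at 1 uM; a lower number here means less inhibition, a higher number more inhibition at the concentration tested (going by the name of the read-out).
Compound 2 `COc1ccncc1-c1ccc2c(O)cccc2c1` gives < 10% in this assay.

Both of these values are limits of the assay, not numbers. Within the data shown here, compound 1 therefore stands at the limit, where every value so far sits (the limit of < 10% in this assay, at which 2 of the 2 values shown sit). Compound 3 `CS(=O)(=O)Nc1ccc(-c2ccc3c(O)cccc3c2)cc1` differs from compound 1 by methanesulfonamido in place of fluoro on an aromatic carbon. Among the measured compounds shown here, no measured pair shows what this change does, so no size or direction can be read from the data, and a step within the scatter is expected. The expected step is a number at least 5 percentage points higher from compound 1 to compound 3 (that floor lies within the scatter). Compound 3 is estimated at 15%, between 0% and 45%.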

Compound 3, a percentage reported as inhibition, at one concentration (the size of the read-out at that concentration, not a potency): 75%
Estimate against measurement, compound 3: 60 percentage points below; the measured number lies above the stated range.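

On an aromatic carbon para to a large group, methanesulfonamido in place of fluoro gives a number at least 65 percentage points higher from compound 1 to compound 3 (beyond the scatter) in this assay. Among these compounds, the earlier compounds showed nothing of the kind, so this is the first sign that the group at this place can change the read-out on the shared core. Only compound 3 stands clear of the limit: the limit of < 10% in this assay, at which 2 of the 3 values shown sit.

As far as these compounds go, whether the step belongs to the whole methanesulfonamido group or to one part of it stays open. An amine or a carboxylic acid at this place, or a longer chain on the sulfur, would begin to separate these possibilities.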